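A few compounds are considered here, and "the series" means these few. Any claim that something is new, unique, unknown or untested is made for them only; others in the source may bear on it.

Among the measured compounds shown here, compound 2, whose structure is `C=CCn1c(=O)/c(=C\c2ccccc2Cl)[nH]c(=O)/c1=C\c1ccccc1OC`, is the one member of this small set of bis-arylidene compounds on the shared core for which a number is available. In a functional assay on BGC-823 cells (Homo sapiens) for cytotoxicity, read by CCK-8 assay, with a stated time of 72 h (a lower number here means a stronger inhibitor, a higher number a weaker inhibitor), compound 2 gives 4600 nM. Two close relatives give no number at all: compound 1, with structure `COc1ccccc1/C=c1/[nH]c(=O)/c(=C\c2ccccc2OC)n(C)c1=O`, is reported in this assay as "not active" (no number reported), and compound 3, with structure `C=CCn1c(=O)/c(=C\c2cc(Br)ccc2F)[nH]c(=O)/c1=C\c1ccccc1OC`, is likewise reported in this assay as "not active" (no number reported). Compound 2 therefore stands alone as the only measurable inhibitor among the three, and nothing in the data ranks it against the other two beyond the fact that they gave no value.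

Compound 4, with structure `C=CCn1c(=O)/c(=C\c2cccc(Br)c2)[nH]c(=O)/c1=C\c1ccccc1OC`, has not yet been tested. It differs from compound 2 in one place: 3-bromophenyl in place of 2-chlorophenyl on a double-bonded chain carbon bound to an aromatic carbon. For the measured compounds named here, no measured pair in the set isolates this exact change, so the direction has to be inferred from the neighbours. The step from compound 2 to compound 4 is expected to be a modest loss of potency, a 1.7-fold higher number from compound 2 to compound 4 (0.24 log units; within the scatter), because compound 3 with its 5-bromo-2-fluorophenyl gave "not active" (no number reported) while only the chloro analogue gave a number. Compound 4 is accordingly estimated at 8000 nM, with a plausible range from 2500 nM to 30000 nM, and a real chance that only a limit is reported.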

Compound 4, half-maximal inhibitory concentration: 5900 nM
Compound 4: the middle estimate sits 1.4-fold (0.13 log units) above what was measured; the measured number falls inside the stated range.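

In this assay, among the compounds shown here, the exchange of 2-chlorophenyl for 3-bromophenyl on a double-bonded chain carbon bound to an aromatic carbon gives a 1.3-fold higher number from compound 2 to compound 4 (0.11 log units; within the scatter) and so leaves the two compounds indistinguishable, which means that compound 2 no longer stands alone as the only compound here with a number. Compound 3, which also carries bromine on the phenyl ring at this place, is reported as "not active" (no number reported) in this assay, whereas compound 4 gives a number, so the presence of bromine on that ring does not by itself decide whether a value is obtained. Nothing shown here offers a measured property that bears on this result.

The step changes both the halogen and its place on the ring at once, so the compounds shown cannot separate the two, and 3-chlorophenyl or 2-bromophenyl would be needed to do so. Also open is how this place responds to a phenyl ring without any halogen, or to one carrying an amine or a carboxylic acid, since every ring shown here bears a halogen or a methoxy group.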